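Pyridin-4-yl in place of 2-nitrophenyl

This account rests on a few compounds, and the source may have more. Where it says the series, first, only, none or still open, it means among the compounds named here.

In a functional assay on MCF7 cells (Homo sapiens) for antiproliferative activity, read by MTT assay, with a stated time of 48 h (on this read-out higher numbers stand for weaker inhibition and lower numbers for stronger inhibition), compound 1 `COc1ccc(C2OC(c3ccc4ccccc4c3)=NN2C(C)=O)cc1` gives 7.35 ug/mL and compound 2 `CC(=O)N1N=C(c2ccc3ccccc3c2)OC1c1ccc(Br)cc1` gives 5.07 ug/mL within the scatter of each other. Compound 3 `CC(=O)N1N=C(c2ccc3ccccc3c2)OC1c1ccccc1[N+](=O)[O-]` at 18.2 ug/mL has the highest number of the three and so the weakest inhibition. Compound 4 `CC(=O)N1N=C(c2ccc3ccccc3c2)OC1c1ccncc1` is not yet measured and carries pyridin-4-yl in place of 2-nitrophenyl on a saturated ring carbon. Two measured steps change the group on that carbon (a 2.5-fold higher number from compound 1 to compound 3 (0.39 log units; beyond the scatter)) and (a 3.6-fold higher number from compound 2 to compound 3 (0.56 log units; beyond the scatter)), both modest yet beyond the scatter. Among the compounds with values here, both leave 2-nitrophenyl with the higher number, but no measured compound carries pyridin-4-yl. The expected move in this assay is therefore smaller and downward (a 1.7-fold lower number from compound 3 to compound 4 (0.22 log units; within the scatter)). Compound 4 is estimated at 11 ug/mL with 5 ug/mL to 26 ug/mL as its likely range.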

Compound 4, half-maximal inhibitory concentration: 2.56 ug/mL
The estimate for compound 4 lay 4.3-fold (0.63 log units) above the measured number; measured number below the stated range.
By their numbers in this assay, from the lowest: compounds 4, 2 and 1 (each within the scatter of the next, the first and the last beyond it); then compound 3.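

In this assay, changing the ring on this saturated ring carbon moves the number further than any earlier step (a 7.1-fold lower number from compound 3 to compound 4 (0.85 log units; beyond the scatter)), and pyridin-4-yl also separates from 4-methoxyphenyl (a 2.9-fold lower number from compound 1 to compound 4 (0.46 log units; beyond the scatter)). Against 4-bromophenyl it does not separate (a 2.0-fold lower number from compound 2 to compound 4 (0.30 log units; within the scatter)), so compound 2 and compound 4 cannot be ranked. No measurement here explains these differences. Still open, from the compounds shown here alone, is how pyridin-3-yl or 4-nitrophenyl would compare on this carbon, which would show whether the place of the ring nitrogen or of the nitro group matters. A piperidine ring here is equally untested by these compounds.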